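Compound 3: an amide group in place of methoxy

A few compounds are considered here, and "the series" means these few. Any claim that something is new, unique, unknown or untested is made for them only; others in the source may bear on it.

- compound 1 `O=C(O)C(=O)Nc1nc(-c2ccc(O)cc2)cs1`: > 3 mg/kg (a limit)
- compound 2 `CCOC(=O)C(=O)Nc1nc(-c2ccc(OC)cc2)cs1`: about 10 mg/kg

For the measured compounds named here, in a functional assay on the whole organism with Rattus norvegicus as the target (a higher number here means that more compound is needed for the effect, a lower number that less compound is needed), compound 2 gives about 10 mg/kg, the only actual number so far. For compound 1 the entry > 3 mg/kg is a limit and not a number. Compound 3 `CCCC(=O)Nc1ccc(-c2csc(NC(=O)C(=O)OCC)n2)cc1` carries (propylcarbonyl)amino in place of methoxy on an aromatic carbon, para to a large group ((propylcarbonyl)amino in place of methoxy on an aromatic carbon). Going by the values given here, no measured step covers this change, so no shift beyond the scatter is expected in this assay, and the expected step is a 1.3-fold lower number from compound 2 to compound 3 (0.10 log units; within the scatter). Compound 3 is estimated at 8 mg/kg, with an expected range of 2 mg/kg to 30 mg/kg.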

Compound 3, dose for half-maximal effect: > 10 mg/kg
Compound 3 ended at the assay's limit; the forecaster's own chance of this, stated with the estimate: 25%; middle value at least 1.2-fold (0.09 log units) away from the limit.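

Replacing methoxy with (propylcarbonyl)amino on an aromatic carbon, para to a large group, gives in this assay a number no lower from compound 2 to compound 3 (the limit leaves the size open). For the compounds shown here, this is the first reading at this position with an amide in place of an ether, and it shows no gain from the larger group. How much is lost cannot be read, as the value for compound 3 is a limit and not a number: the limit of > 10 mg/kg in this assay, at which 1 of the 3 values shown sits.

On these data alone, whether an amine or a shorter acetylamino group on the same carbon would lower the dose remains open. So does the effect of a longer chain there.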